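Benzylic vinyl sulfones: nitro to trifluoromethoxy exchange

The source may hold more compounds than are shown below. What is called first, only, known or untested is meant among the compounds shown, and "the series" means these compounds.

Working notes on a small set of styryl benzyl sulfones. Compound 1 `COc1ccc(/C=C/S(=O)(=O)Cc2ccc(OC)cc2)cc1` reaches only a limit, giving > 20000 nM in a functional assay on DU-145 cells (Homo sapiens) for antiproliferative activity, read by trypan blue exclusion; a higher number here means a weaker inhibitor, a lower number a stronger inhibitor. Compound 3 `COc1ccc(CS(=O)(=O)/C=C/c2ccc(OC)cc2OC)cc1` likewise reaches only a limit, giving > 20000 nM in this assay. The step that the two limits leave unreadable from compound 1 to compound 3 is therefore not readable. For the measured compounds named here, compound 2 `COc1cc(OC)c(/C=C/S(=O)(=O)Cc2ccc([N+](=O)[O-])cc2)c(OC)c1` gives 15000 nM in this assay, the only number in the set, standing just inside (the limit of > 20000 nM in this assay, at which 2 of the 3 values shown sit). Compound 4 `COc1cc(OC)c(/C=C/S(=O)(=O)Cc2ccc(OC(F)(F)F)cc2)c(OC)c1` differs from compound 2 by trifluoromethoxy in place of nitro on an aromatic carbon. Going by the values given here, no measured step touches this exchange; the single step available is unreadable and the single number sits close to the limit. The expectation for compound 4 is accordingly no movement beyond the scatter, with the step of a 1.3-fold higher number from compound 2 to compound 4 (0.12 log units; within the scatter) expected to stay flat. Compound 4 is estimated at 20000 nM, within 7000 nM to 60000 nM.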

Compound 4, half-maximal inhibitory concentration: 4000 nM
Compound 4: the middle estimate sits 5.0-fold (0.70 log units) above what was measured; measured number below the stated range.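

For the compounds shown here, the exchange at this aromatic carbon, para to a large group, gives the first readable step in the set: in this assay it is a 3.8-fold lower number from compound 2 to compound 4 (0.57 log units; beyond the scatter). Going by these compounds alone, the number therefore responds to the group at this position, and nitro is not the only group there that gives a measurable value. The step between compound 1 and compound 3 still cannot be read: the limit of > 20000 nM in this assay, at which 2 of the 4 values shown sit.

From the compounds shown here alone, whether an amine or a carboxylic acid at this position would move the number further stays open. Also open, going by these compounds, is whether the same exchange would give a similar step on the core of compound 1.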